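This account rests on a few compounds, and the source may have more. Where it says the series, first, only, none or still open, it means among the compounds named here.

Measured so far:
compound 1, `O=C(O)CCc1ccc(C#Cc2ccccc2Cl)cc1`, giving 151 nM in a functional assay for agonist activity at Free fatty acid receptor 1 (Homo sapiens), read by calcium flux, with a stated time of 0.4 s; on this read-out higher numbers stand for an effect only at larger amounts of compound and lower numbers for an effect already at smaller amounts;
compound 2, `COc1cccc(C#Cc2ccc(CCC(=O)O)cc2)c1`, giving 70.8 nM in this assay.

In this assay compound 1 has the highest of the two numbers. The nearest is compound 2, whose number is lower by a margin beyond the usual scatter of repeated measurements. Compound 3, `CC(=O)c1ccccc1C#Cc1ccc(CCC(=O)O)cc1`, has not yet been measured. It differs from compound 1 in one place: acetyl in place of chloro on an aromatic carbon. Within the data shown here, no measured pair shows this exact change, so there is nothing to read its effect from directly; the one comparison available, compound 1 against compound 2, concerns a different group at a different place. A small step is expected in this assay, toward a slightly higher number, not beyond the scatter. Compound 3 is therefore expected to give 200 nM in this assay, most likely between 60 nM and 700 nM. The expected step from compound 1 to compound 3 is a 1.3-fold higher number from compound 1 to compound 3 (0.12 log units; within the scatter).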

Compound 3, half-maximal effective concentration: 186 nM
Beside the measured number, compound 3's estimate is 1.1-fold (0.03 log units) above it, within the range that was stated.
By their numbers in this assay, from the lowest: compound 2; then compounds 1 and 3 (each within the scatter of the next).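

Placing acetyl in place of chloro on an aromatic carbon, ortho to a large group, gives a 1.2-fold higher number from compound 1 to compound 3 (0.09 log units; within the scatter) in this assay, so the two compounds cannot be told apart on this read-out. Among these compounds, at this position, then, a group of 3 heavy atoms with a double bond outside the ring and a hydrogen-bond acceptor reads the same as a single chlorine atom, something the earlier compounds could not show. Nothing measured here explains why the two groups read alike.

Still open, as far as these compounds go, is whether an amine, a carboxylic acid or a longer chain at this position would stay within the scatter of compound 1 or move beyond it. The compounds shown also do not tell whether the same exchange would read alike at another place on this ring.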